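This account rests on a few compounds, and the source may have more. Where it says the series, first, only, none or still open, it means among the compounds named here.

Measured compounds:
- compound 1, `COC(=O)c1ccc(N(Cc2cnc(C3CCCCC3)cn2)C(=O)[C@H]2CCN2S(=O)(=O)c2c(F)c(F)c(F)c(F)c2F)c(F)c1`, gives 8900 nM in a functional assay on MCF7 cells (Homo sapiens) for antiproliferative activity, with a stated time of 72 h; a higher number here means that more compound is needed for the effect, a lower number that less compound is needed
- compound 2, `O=C(NO)c1ccc(N(Cc2ccc(C3CCCCC3)cc2)C(=O)[C@H]2CCN2S(=O)(=O)c2c(F)c(F)c(F)c(F)c2F)cc1O`, gives 9700 nM in this assay
- compound 3, `CNC(=O)c1ccc(N(Cc2ccc(C3CCCCC3)cn2)C(=O)[C@H]2CCN2S(=O)(=O)c2c(F)c(F)c(F)c(F)c2F)c(F)c1`, gives "not determined" (no result reported) in this assay, that is, no reported number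

Compound 3 therefore stands nowhere on the numbers shown; the only anchors are compound 1 and compound 2, whose two values lie within the usual scatter of each other. Compound 4, `O=C([C@H]1CCN1S(=O)(=O)c1c(F)c(F)c(F)c(F)c1F)N(Cc1ccc(C2CCCCC2)cn1)c1cc2[nH]ncc2cc1F`, differs from compound 3 in one place: 5-fluoro-1H-indazol-6-yl in place of 2-fluoro-4-(methylcarbamoyl)phenyl on an amide-type nitrogen. With no measured step between any two of these compounds, the size of the change from compound 3 to compound 4 in this assay cannot be taken from data; the expectation is a step no larger than the scatter, in either direction. Compound 4 is estimated to give 6000 nM, within a range of 1500 nM to 20000 nM.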

Compound 4, half-maximal effective concentration: 4800 nM
Compound 4: the middle estimate sits 1.3-fold (0.10 log units) above what was measured; the measured number falls inside the stated range.
By their numbers in this assay, from the lowest: compounds 4, 1 and 2 (each within the scatter of the next, the first and the last beyond it).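

No new step can be read from compound 4 against compound 3, compound 1 or compound 2. From the compounds shown here alone, what 5-fluoro-1H-indazol-6-yl does in place of 2-fluoro-4-(methylcarbamoyl)phenyl in this assay stays open. Nothing shown explains these values.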